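Removing a methoxy from an indole sulfone: what to expect

The source may hold more compounds than are shown below. What is called first, only, known or untested is meant among the compounds shown, and "the series" means these compounds.

Measured so far:
compound 1 `CC(=O)/C(=C\c1c(-c2ccccc2)[nH]c2ccccc12)S(=O)(=O)c1ccccc1` — 2100 nM
compound 2 `COc1ccc2[nH]c(-c3ccccc3)c(/C=C(\C#N)S(=O)(=O)c3ccccc3)c2c1` — 19400 nM

In a functional assay on Malme-3M cells (Homo sapiens) for inhibition, read by sulforhodamine B assay, with a stated time of 48 h (on this read-out higher numbers stand for weaker inhibition of growth and lower numbers for stronger inhibition of growth), compound 1 gives 2100 nM. Compound 2 gives 19400 nM in this assay and stands highest of the two numbers, which are far enough apart to lie beyond the usual scatter. The two compounds differ in more than one place, so no single change can be credited for the gap.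

Compound 3 `N#C/C(=C\c1c(-c2ccccc2)[nH]c2ccccc12)S(=O)(=O)c1ccccc1` is the not yet measured compound. It differs from compound 2 in one place: hydrogen in place of methoxy on an aromatic carbon of the shared core, at a position meta to a fused ring and para to a fused ring.

Going by the values given here, no measured pair shows this change on its own, so the direction in this assay is open. Because compound 1, which also lacks the methoxy, gives 2100 nM, a moderate downward step is expected, as a 2.4-fold lower number from compound 2 to compound 3 (0.38 log units; beyond the scatter). Compound 3 is estimated at 8000 nM, with a range from 2500 nM to 25000 nM.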

Compound 3, concentration for 50% growth inhibition: 8400 nM
Estimate against measurement, compound 3: 1.1-fold (0.02 log units) below; low and high end bracket the measured number.
By their numbers in this assay, from the lowest: compound 1; then compound 3; then compound 2.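

In this assay, replacing methoxy with hydrogen on this aromatic carbon, meta to a fused ring and para to a fused ring, gives a 2.3-fold lower number from compound 2 to compound 3 (0.36 log units; beyond the scatter), so growth inhibition does not depend on the methoxy and is stronger without it in this pair. The other single change, cyano in place of acetyl on the double-bonded chain carbon, gives a 4.0-fold higher number from compound 1 to compound 3 (0.60 log units; beyond the scatter), so the acetyl goes with stronger inhibition in this pair. Nothing measured here explains why either change shifts the number.

Going by these compounds, it remains open whether a different group at the methoxy position, such as an amine or a longer ether chain like ethoxy, would give a lower or higher number than hydrogen. It is also unknown whether removing the methoxy would have a similar effect with acetyl in place of cyano.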